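A few compounds are considered here, and "the series" means these few. Any claim that something is new, unique, unknown or untested is made for them only; others in the source may bear on it.

Compound 3 `Cc1cn(C2CC(N=[N+]=[N-])C(COC(=O)OCCCO)O2)c(=O)[nH]c1=O` stands lowest of the three compounds in a physicochemical assay for lipophilicity; on this read-out lower numbers stand for lower lipophilicity and higher numbers for higher lipophilicity: compound 3 gives -0.98, whereas compound 1 `CCCCOC(=O)OCC1OC(n2cc(C)c(=O)[nH]c2=O)CC1N=[N+]=[N-]` gives 1.02 and compound 2 `Cc1cn(C2CC(N=[N+]=[N-])C(COC(=O)OCCCCCCCCO)O2)c(=O)[nH]c1=O` gives 1.14. Compound 4 `Cc1cn(C2CC(N=[N+]=[N-])C(COC(=O)OCCCC(=O)O)O2)c(=O)[nH]c1=O` differs from compound 3 by carboxy in place of hydroxy on a saturated chain carbon, three bonds along the chain from an oxygen next to a carbonyl group. Among the measured compounds shown here, no measured step exchanges hydroxy for carboxy directly. The steps that come closest, a number 2.00 log units lower from compound 1 to compound 3 (beyond the scatter) and a number 2.12 log units lower from compound 2 to compound 3 (beyond the scatter), were both large drops when hydroxy entered; here hydroxy gives way to carboxy, a group that likewise carries one hydrogen-bond donor and one hydrogen-bond acceptor, so only a modest further move, probably downward, is expected. Compound 4 is therefore estimated at -1.3, within a range from -2.5 to -0.3, which corresponds to an expected step of a number 0.32 log units lower from compound 3 to compound 4 (beyond the scatter).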

Compound 4, partition coefficient: -0.55
For compound 4 the middle estimate is 0.75 log units below the measured one; low and high end bracket the measured number.
By their numbers in this assay, from the lowest: compound 3; then compound 4; then compounds 1 and 2 (each within the scatter of the next).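

In this assay, among the compounds shown here, carboxy in place of hydroxy on a saturated chain carbon, three bonds along the chain from an oxygen next to a carbonyl group, gives the first direct exchange between these two groups, with a number (a number 0.43 log units higher from compound 3 to compound 4 (beyond the scatter)). Measured against methyl and 5-hydroxypentyl at that place, carboxy still brings large drops (a number 1.57 log units lower from compound 1 to compound 4 (beyond the scatter); a number 1.69 log units lower from compound 2 to compound 4 (beyond the scatter)). No supporting measurement accounts for the difference between carboxy and hydroxy. From the compounds shown here alone, whether a methyl ester or an amine on this chain would stand nearer compound 3 or compound 1 remains open, as does the effect of a longer chain ending in carboxy.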